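Compound 3 to compound 4: removing the methoxy group

A few compounds are considered here, and "the series" means these few. Any claim that something is new, unique, unknown or untested is made for them only; others in the source may bear on it.

compound 1 `CN(C)C(=O)c1cc2cnc(Nc3ccc(NC(=O)C4(C(=O)Nc5ccc(Cl)c(C(F)(F)F)c5)CC4)cc3)nc2n1C1CCCC1`: 88.1%
compound 2 `CN(C)C(=O)c1cc2cnc(Nc3ccc(NC(=O)C4(C(=O)Nc5cccc(C#N)c5)CC4)cc3)nc2n1C1CCCC1`: 73.6%
compound 3 `COc1cccc(NC(=O)C2(C(=O)Nc3ccc(Nc4ncc5cc(C(=O)N(C)C)n(C6CCCC6)c5n4)cc3)CC2)c1`: 96%

These three compounds share one core and differ only in the ring on an amide nitrogen. All were tested in a functional assay on A549 cells (Homo sapiens) for inhibition, read by CCK-8 assay, with a stated time of 72 h, tested at 10 uM; on this read-out higher numbers stand for more inhibition of growth at the one concentration tested and lower numbers for less inhibition of growth. The gap a number 7.9 percentage points higher from compound 1 to compound 3 (within the scatter) shows that compound 3 and compound 1 cannot be told apart, so compound 3 belongs to the upper pair, with compound 2 clearly apart from both.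

Compound 4 `CN(C)C(=O)c1cc2cnc(Nc3ccc(NC(=O)C4(C(=O)Nc5ccccc5)CC4)cc3)nc2n1C1CCCC1` is the next case: hydrogen in place of methoxy on an aromatic carbon. Here hydrogen takes the place of methoxy on an aromatic carbon, meta to a large group, turning 3-methoxyphenyl into phenyl. For the measured compounds named here, no measured step tests this exact change. The nearest evidence is a number 22.4 percentage points higher from compound 2 to compound 3 (beyond the scatter), where methoxy replaces cyano, and a number 14.5 percentage points lower from compound 1 to compound 2 (beyond the scatter), which also changes this ring. Both show that such changes can move the read-out by a modest amount, although a number 7.9 percentage points higher from compound 1 to compound 3 (within the scatter) shows that a change here need not exceed the scatter. A modest fall in this assay therefore seems more likely than a rise. The expected change is a number 12 percentage points lower from compound 3 to compound 4 (beyond the scatter), and this is only an estimate. For compound 4 the estimated value is 84%, with an expected range from 66% to 97%.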

Compound 4, percent growth inhibition at one concentration: 88.8%
For compound 4 the middle estimate is 4.8 percentage points below the measured one; measured number inside the range.
By their numbers in this assay, from the lowest: compound 2; then compounds 1, 4 and 3 (each within the scatter of the next).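

In this assay the plain phenyl ring cannot be told apart from the two substituted rings of the upper group. The read-out gives a number 7.2 percentage points lower from compound 3 to compound 4 (within the scatter) and also a number 0.7 percentage points higher from compound 1 to compound 4 (within the scatter) so neither the methoxy group nor the chloro and trifluoromethyl groups are needed to reach this level of growth inhibition at the one concentration tested. Compound 4 also gives the earlier gap between compound 2 and compound 3 a reference point, a ring carrying no group at all, and the step of a number 15.2 percentage points higher from compound 2 to compound 4 (beyond the scatter) places that ring with the upper compounds. Among these four, then, the lower number goes with the cyano group rather than the higher numbers going with methoxy, and compound 2 alone stands apart from the rest.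

The compounds shown leave open whether an amine or a carboxylic acid on this ring, or a longer chain such as ethoxy in place of methoxy, would stay with the upper group or sit apart as compound 2 does. No measurement at hand speaks to why the cyano compound stands apart.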